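A Second Fluoro on the Benzyl Group of Compound 2

The compounds below may be only part of what the source reports. "The series", "measured", "known", "first", "only" and "open" are said of these compounds alone.

Within the data shown here, compound 2 `Fc1ccc(CNc2nc(Nc3cc(C4CC4)[nH]n3)c3ccccc3n2)cc1` stands at the lower of the two numbers so far: in an assay for inhibition of high affinity nerve growth factor receptor (Homo sapiens), read by HTRF, with a stated time of 30 min, in the presence of a further agent that is not named here (on this read-out lower numbers stand for stronger inhibition and higher numbers for weaker inhibition), compound 2 gives 40 nM, while compound 1 `Cc1cc(Nc2nc(NCc3ccc(F)cc3F)nc3ccccc23)n[nH]1` gives 200 nM, a higher number beyond the usual scatter. Compound 3 `Fc1ccc(CNc2nc(Nc3cc(C4CC4)[nH]n3)c3ccccc3n2)c(F)c1` differs from compound 2 by fluoro in place of hydrogen on an aromatic carbon, so that the 4-fluorobenzyl becomes a 2,4-difluorobenzyl. Among the measured compounds shown here, no measured pair shows this change on its own, and compound 1 carries the 2,4-difluorobenzyl together with a different group on the shared core, so that pair speaks to no single change. The expected step is a 1.3-fold higher number from compound 2 to compound 3 (0.10 log units; within the scatter), within the scatter. Compound 3 is estimated at 50 nM, with a range from 20 nM to 150 nM.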

Compound 3, half-maximal inhibitory concentration: 4.7 nM
Compound 3: middle estimate off by 11-fold (1.03 log units), on the high side, outside the stated range (below it).
By their numbers in this assay, from the lowest: compound 3; then compound 2; then compound 1.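

In this assay, among these compounds, fluoro in place of hydrogen on the aromatic carbon ortho to a large group gives an 8.5-fold lower number from compound 2 to compound 3 (0.93 log units; beyond the scatter) and thus shows, as no earlier pair could, that this position on the 4-fluorobenzyl responds strongly to one added fluorine. Among the compounds shown here, with the 2,4-difluorobenzyl held constant, cyclopropyl in place of methyl gives a 43-fold lower number from compound 1 to compound 3 (1.63 log units; beyond the scatter) and so isolates that group change for the first time. Nothing available explains either step. The compounds shown leave open how chloro or methoxy would fare at this position, and how ethyl would compare with cyclopropyl and methyl on the shared core.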